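Ether aryl variation in the shared series

The source may hold more compounds than are shown below. What is called first, only, known or untested is meant among the compounds shown, and "the series" means these compounds.

In a functional assay for agonist activity at Free fatty acid receptor 1 (Homo sapiens), read by FLIPR, in the presence of a further agent that is not named here (a lower number here means that less compound is needed, a higher number that more compound is needed for the effect), compound 2 `O=C1NC(=O)C(Cc2ccc(Oc3ccc(F)cc3)cc2)S1` gives 480 nM. Compound 1 `O=C1NC(=O)C(Cc2ccc(Oc3cccc(Cl)c3)cc2)S1` gives 318 nM in this assay. Among the measured compounds shown here, of the two numbers so far, compound 2 carries the higher one, but the step of a 1.5-fold higher number from compound 1 to compound 2 (0.18 log units; within the scatter) keeps the pair within the scatter, so the two are not separated. Compound 3 `O=C1NC(=O)C(Cc2ccc(Oc3ccc(Cl)cn3)cc2)S1` is not yet measured. Its change from compound 2 is 5-chloropyridin-2-yl in place of 4-fluorophenyl on an oxygen on an aromatic ring. For the measured compounds named here, the only measured step touching this place is a 1.5-fold higher number from compound 1 to compound 2 (0.18 log units; within the scatter), an exchange of one substituted phenyl for another on an oxygen on an aromatic ring that stayed within the scatter. No measured exchange of a phenyl for a pyridyl exists in the series. On that basis no step beyond the scatter is expected for compound 3 in this assay, that is a 1.1-fold lower number from compound 2 to compound 3 (0.06 log units; within the scatter). Compound 3 is therefore estimated at 420 nM, with a range of 150 nM to 1200 nM.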

Compound 3, half-maximal effective concentration: 1870 nM
Beside the measured number, compound 3's estimate is 4.5-fold (0.65 log units) below it, outside the stated range (above it).
By their numbers in this assay, from the lowest: compounds 1 and 2 (each within the scatter of the next); then compound 3.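

In this assay, the aryl group on this oxygen is not indifferent to every exchange: the earlier exchange between two substituted phenyl groups stayed within the scatter, whereas the 5-chloropyridin-2-yl group gives a 3.9-fold higher number from compound 2 to compound 3 (0.59 log units; beyond the scatter) and a 5.9-fold higher number from compound 1 to compound 3 (0.77 log units; beyond the scatter). Among the compounds shown here, of the three groups, only the one with a ring hetero atom and a hydrogen-bond acceptor stands apart, and compound 3 needs more compound for the effect than either compound 1 or compound 2. The data shown offer no measurement that accounts for this shift.

Both new steps change the ring nitrogen and the halogen together, so their separate contributions cannot be read. A fluoropyridinyl group on the same oxygen would test whether the higher number follows the pyridine ring or the chlorine.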